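The source may hold more compounds than are shown below. What is called first, only, known or untested is meant among the compounds shown, and "the series" means these compounds.

Compound 1 `CCCn1c(Cc2cc(OC)c(OC)c(OC)c2)nc2c(N)ncnc21` carries the shared core of this small set and in a functional assay on MCF7 cells (Homo sapiens) for antiproliferative activity (a higher number here means a weaker inhibitor, a lower number a stronger inhibitor), compound 1 gives 46800 nM. Compound 2 `CCCn1c(Cc2cc(OC)c(OC)c(OC)c2)nc2c(N)nc(F)nc21` adds a fluoro in place of hydrogen on an aromatic carbon and gives 25100 nM, so that a 1.9-fold lower number from compound 1 to compound 2 (0.27 log units; within the scatter). Compound 3 `COc1cc(Cc2nc3c(N)ncnc3n2CC2(C)CC2)cc(OC)c1OC` instead carries 1-methylcyclopropyl in place of ethyl on a saturated chain carbon bound to an aromatic nitrogen and gives 112000 nM, so that a 2.4-fold higher number from compound 1 to compound 3 (0.38 log units; beyond the scatter). Compound 2 thus shows the lowest of the three numbers, though its gap to compound 1 lies within the scatter and only its gap to compound 3 lies beyond it.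

Compound 4 `C=CCCn1c(Cc2cc(OC)c(OC)c(OC)c2)nc2c(N)nc(F)nc21` has not yet been measured. It differs from compound 2 as follows: vinyl in place of methyl on a saturated chain carbon, two bonds along the chain from an aromatic nitrogen. For the measured compounds named here, the only measured step that touches the chain on the aromatic nitrogen is the one to compound 3, and it moved the number modestly upward. The change from propyl to but-3-en-1-yl is a smaller one than that, so a small step upward, or none beyond the scatter, is expected in this assay. Compound 4 is therefore estimated at 32000 nM, with a range from 12000 nM to 85000 nM, which means an expected step of a 1.3-fold higher number from compound 2 to compound 4 (0.11 log units; within the scatter).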

Compound 4, half-maximal inhibitory concentration: 33100 nM
For compound 4 the middle estimate is 1.0-fold (0.01 log units) below the measured one; the range from low to high includes it.
By their numbers in this assay, from the lowest: compounds 2, 4 and 1 (each within the scatter of the next); then compound 3.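

In this assay the but-3-en-1-yl chain of compound 4 sits close to the propyl chain of compound 2 (a 1.3-fold higher number from compound 2 to compound 4 (0.12 log units; within the scatter)), so the change between these two chains is not resolved by this read-out. The only earlier variation of the chain on the aromatic nitrogen was the 1-methylcyclopropyl group (a 2.4-fold higher number from compound 1 to compound 3 (0.38 log units; beyond the scatter)), and compound 4 adds that an unbranched chain with one more carbon and a double bond outside aromatic rings gives no step beyond the scatter, although this rests on a single pair of compounds. Nothing measured here accounts for this result or shows what the double bond itself contributes.

As far as these compounds go, it remains open whether a saturated butyl chain, a chain ending in an alkyne, or one ending in a hydroxyl group or an amine would also stay within the scatter of compound 2 at this place. Also open, from the compounds shown here alone, is whether the but-3-en-1-yl chain would read the same on the core of compound 1, which lacks the fluoro group.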